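The source may hold more compounds than are shown below. What is called first, only, known or untested is meant among the compounds shown, and "the series" means these compounds.

Working notes on the series. In an ADME assay for permeability, using PAMPA, with a stated time of 6 h, at pH 7.4 (on this read-out lower numbers stand for lower permeability and higher numbers for higher permeability), compound 1 (`C#CCNC1=CC(=O)c2c(O)ccc(O)c2C1=O`) gives 43.3 10^-6 cm/s and compound 2 (`C#CCNC1=CC(=O)c2cccc(OCc3ccccc3)c2C1=O`) gives 25.5 10^-6 cm/s so compound 2 stands within the scatter of compound 1, and neither can be ranked on these numbers. Compound 3 (`C#CCNC1=CC(=O)c2cccc(OCC)c2C1=O`) is not yet measured. It differs from compound 2 by benzyloxy to ethoxy: methyl in place of phenyl on a saturated chain carbon bound to an oxygen on an aromatic ring with methyl in place of phenyl on a saturated chain carbon bound to an oxygen on an aromatic ring. Going by the values given here, no measured pair shows this change, so the expectation rests only on the two values in hand. In this assay no step beyond the scatter is expected. The estimated step of a 1.2-fold higher number from compound 2 to compound 3 (0.07 log units; within the scatter) is expected to be small, with a slight upward lean at most. Compound 3 is estimated at 30 10^-6 cm/s (expected range 14 10^-6 cm/s to 55 10^-6 cm/s).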

Compound 3, apparent permeability: 18.5 10^-6 cm/s
The estimate for compound 3 lay 1.6-fold (0.21 log units) above the measured number; the range from low to high includes it.
By their numbers in this assay, from the lowest: compounds 3, 2 and 1 (each within the scatter of the next, the first and the last beyond it).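

In this assay, methyl in place of phenyl on a saturated chain carbon bound to an oxygen on an aromatic ring gives a 1.4-fold lower number from compound 2 to compound 3 (0.14 log units; within the scatter) and so gives the series its first step between compounds that differ in one place. Benzyloxy to ethoxy removes the six-membered aromatic ring of the side group, yet the read-out shows no change that can be told from the scatter. Nothing in hand bears on why this step is small.

The compounds shown leave open whether this position stays as flat with an amine or a carboxylic acid on the chain, or with a longer chain such as butoxy. They also leave open whether the same change gives a similar step on a core carrying other groups.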